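Replacing the pyrimidine with a carbamate on the piperidine nitrogen

The compounds below may be only part of what the source reports. "The series", "measured", "known", "first", "only" and "open" are said of these compounds alone.

Of the compounds shown here, two have been measured in a functional assay on CHO-K1 cells for agonist activity at Glucose-dependent insulinotropic receptor (Homo sapiens), read by HTRF and cAMP accumulation, with a stated time of 30 min; a higher number here means a larger maximal response, a lower number a smaller maximal response. Compound 1, `CCc1cnc(N2CCC(CCCNc3ccc4c(c3)C(=O)CC4)CC2)nc1`, stands highest of the two; in this assay compound 1 gives 113%. The other measured compound is compound 2, `CC(C)(C)OC(=O)N1CCC(CCCNc2ccc3c(c2)S(=O)(=O)CC3)CC1`; in this assay compound 2 gives 25%, a number well beyond the scatter below that of compound 1. Among the measured compounds shown here, compound 2 differs from compound 1 in two places at once, so the two values show only that the pair sits far apart and not which change carries the gap.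

Compound 3, `CC(C)(C)OC(=O)N1CCC(CCCNc2ccc3c(c2)C(=O)CC3)CC1`, is not yet measured. It keeps the core of compound 1 and differs from it in one place: tert-butoxycarbonyl in place of 5-ethylpyrimidin-2-yl on an amine nitrogen in a ring. For the measured compounds named here, no step between measured compounds isolates this change. Because compound 2, which also carries tert-butoxycarbonyl on the ring nitrogen, gives 25%, a large fall in this assay is expected, in the direction of a smaller maximal response. The expected step is a number 73 percentage points lower from compound 1 to compound 3 (beyond the scatter). Compound 3 is estimated at 40%, with a range from 10% to 90%.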

Compound 3, largest response reached (Emax), in percent of the reference or control that the assay uses: 98%
Compound 3: the middle estimate sits 58 percentage points below what was measured, outside the stated range (above it).
By their numbers in this assay, from the lowest: compound 2; then compound 3; then compound 1.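

On the ring nitrogen, the aromatic 5-ethylpyrimidin-2-yl group proves not to be needed for a large maximal response: in this assay, tert-butoxycarbonyl in its place gives only a modest fall, a number 15 percentage points lower from compound 1 to compound 3 (beyond the scatter), although that fall lies beyond the usual scatter. Compound 3 also forms a one-place pair with compound 2, which carries the same tert-butoxycarbonyl group but has a sulfone where compound 3 has the carbonyl of the shared core; compound 2 gives 25% and compound 3 gives 98%, so the low value of compound 2 cannot be read as a general mark of tert-butoxycarbonyl at this position and goes instead with the change in the core. No available evidence explains either difference.

Going by these compounds, it remains open whether the sulfone would give a similarly low response alongside 5-ethylpyrimidin-2-yl, a pairing that would test whether the two places act independently. Also open, on these data alone, is how other groups on this ring nitrogen, such as an isopropyl carbamate, an amide or a pyridine ring, would compare with these two.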